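Swapping the Urea Aryl: An Expected Small Step

The source may report more compounds than this note shows. Statements on the series, on what has been measured and on what is new or still open speak of the compounds shown alone.

Of the compounds shown here, three have been measured in a functional assay on NCI-H460 cells (Homo sapiens) for inhibition, read by sulforhodamine B assay, with a stated time of 48 h; a lower number here means a stronger inhibitor of growth, a higher number a weaker inhibitor of growth. Compound 1 `O=C(Nc1cccc(-n2cc(-c3ccncc3)c(-c3ccc(Cl)c(O)c3)n2)c1)Nc1ccc(Cl)c(Cl)c1` gives 993 nM, which places it second highest of the three numbers. Compound 3 `COc1cc(-c2nn(-c3cccc(NC(=O)c4ccccc4)c3)cc2-c2ccncc2)ccc1Cl` gives 394 nM, a lower number than compound 1 by more than the scatter, while compound 2 `COc1cc(-c2nn(-c3cccc(NC(=O)c4ccc(Cl)c(C(F)(F)F)c4)c3)cc2-c2ccncc2)ccc1Cl` gives 3470 nM, a higher number than compound 1 by more than the scatter. For the measured compounds named here, the only step between two compounds that differ in a single place is an 8.8-fold lower number from compound 2 to compound 3 (0.94 log units; beyond the scatter); it concerns the group on the carbonyl carbon of an amide, not the nitrogen altered here, and the two compounds carry a methoxy rather than a hydroxy group, so it bears only loosely on the present question.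

Compound 4 `O=C(Nc1cccc(-n2cc(-c3ccncc3)c(-c3ccc(Cl)c(O)c3)n2)c1)Nc1cccc(C(F)(F)F)c1` differs from compound 1 in one place: 3-(trifluoromethyl)phenyl in place of 3,4-dichlorophenyl on an amide-type nitrogen. Going by the values given here, no measured pair isolates this change, so the direction cannot be read from the data. Compound 4 is therefore expected to give 1000 nM, between 400 nM and 2500 nM. The expected step is a 1.0-fold higher number from compound 1 to compound 4 (0.00 log units; within the scatter), not beyond the scatter.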

Compound 4, concentration for 50% growth inhibition: 1180 nM
Beside the measured number, compound 4's estimate is 1.2-fold (0.07 log units) below it; measured number inside the range.
By their numbers in this assay, from the lowest: compound 3; then compounds 1 and 4 (each within the scatter of the next); then compound 2.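

For the compounds shown here, the step of a 1.2-fold higher number from compound 1 to compound 4 (0.07 log units; within the scatter) in this assay is the first direct reading of a change on this amide-type nitrogen, and it shows that 3,4-dichlorophenyl and 3-(trifluoromethyl)phenyl cannot be told apart here. Going by these compounds alone, the only earlier single-place step, an 8.8-fold lower number from compound 2 to compound 3 (0.94 log units; beyond the scatter), lay beyond the scatter, but it concerned a different place, a carbonyl carbon, in compounds carrying methoxy rather than hydroxy, so this flat result holds only for the pair of compound 1 and compound 4. No evidence is available to explain this result.

The compounds shown leave open whether a phenyl ring bearing a carboxylic acid or an amine would stay level with these two groups on this nitrogen. They also leave open whether the same exchange would read as flat in the methoxy compounds.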